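Carbamate in place of benzyl amide on the shared core

The source may hold more compounds than are shown below. What is called first, only, known or untested is meant among the compounds shown, and "the series" means these compounds.

Measured so far:
compound 1 `Cc1cc(C(=O)NCc2ccccc2)nn1Cc1cc(Cl)ccc1OCc1ccccc1` > 3.7
compound 2 `Cc1cc(C(=O)NN2CCCCC2)nn1Cc1cc(Cl)ccc1OCC(C)C` 3.3

In a physicochemical assay for lipophilicity, at pH 7.4 (a lower number here means a more polar compound, a higher number a more lipophilic compound), compound 1 returns only a limit, > 3.7; it is one of the limit of > 3.7 in this assay, at which 1 of the 2 values shown sits. Compound 2 gives a number, 3.3, and no single change separates it from compound 1, so the two values stand side by side only. Compound 3 `Cc1cc(NC(=O)OCC(C)C)nn1Cc1cc(Cl)ccc1OCc1ccccc1` differs from compound 1 by (isobutoxycarbonyl)amino in place of benzylcarbamoyl on an aromatic carbon. A small step downward in this assay is expected, about a number at least 0.20 log units lower from compound 1 to compound 3 (that floor lies within the scatter), near the edge of the scatter. For compound 3 the estimate in this assay is 3.5, between 2.9 and 4.1.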

Compound 3, distribution coefficient: 3.3
Beside the measured number, compound 3's estimate is 0.20 log units above it; measured number inside the range.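

In this assay, (isobutoxycarbonyl)amino in place of benzylcarbamoyl on this aromatic carbon of the shared core gives a number at least 0.40 log units lower from compound 1 to compound 3 (beyond the scatter). Among these compounds, this is the first single-place step, and it shows that the read-out responds to the group on this carbon. The full size of the step cannot be read, because the value of compound 1 is a limit: the limit of > 3.7 in this assay, at which 1 of the 3 values shown sits.

The compounds shown do not separate the loss of the aromatic ring from the change to the carbamate linkage. Where an amine or a carboxylic acid on this carbon would fall remains open.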